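This account rests on a few compounds, and the source may have more. Where it says the series, first, only, none or still open, it means among the compounds named here.

Compound 1 `Cc1nsc2ncn([C@H]3C[C@H](O)[C@@H](CO)O3)c12` and compound 2 `CSc1nc2snc(C)c2n1[C@H]1C[C@H](O)[C@@H](CO)O1` share one core, while compound 3 `Cc1nsc2c1ncn2[C@@H]1O[C@H](CO)[C@@H](O)[C@H]1O` and compound 4 `CSc1nc2c(C)nsc2n1[C@@H]1O[C@H](CO)[C@@H](O)[C@H]1O` share another; the difference between the two cores is not broken down here. In a functional assay on HFF cells (Homo sapiens) for inhibition (on this read-out lower numbers stand for stronger inhibition and higher numbers for weaker inhibition), compound 1 gives only a limit of the assay, > 100000 nM. In this assay compound 2 gives 32000 nM, and compound 3 gives 150000 nM. The change from compound 1 to compound 2 is methylsulfanyl in place of hydrogen on an aromatic carbon; it made an at least 3.1-fold lower number from compound 1 to compound 2 (0.49 log units; beyond the scatter), with its starting point sitting at the limit of > 100000 nM in this assay, at which 1 of the 3 values shown sits. Compound 4 carries the same kind of change, (methylsulfanyl in place of hydrogen on an aromatic carbon), differing only in that the change sits next to the ring atom that bears a group of 9 heavy atoms rather than 8. Resting on an at least 3.1-fold lower number from compound 1 to compound 2 (0.49 log units; beyond the scatter), compound 4 is expected to take a step of similar size, a 3.8-fold lower number from compound 3 to compound 4 (0.57 log units; beyond the scatter). Compound 4 is estimated at 40000 nM, between 15000 nM and 150000 nM.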

Compound 4, half-maximal inhibitory concentration: > 100000 nM
Compound 4: no number, only a limit; the forecaster's own chance of this, stated with the estimate: 25%; middle value at least 2.5-fold (0.39 log units) away from the limit.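

In this assay compound 4 gives only a limit of the assay, > 100000 nM, so the step from compound 3 to compound 4 cannot be read. The compounds shown leave open whether methylsulfanyl in place of hydrogen lowers the number on the core of compound 3 at all.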